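Swapping a nitrile for two chlorines on an amide

This account rests on a few compounds, and the source may have more. Where it says the series, first, only, none or still open, it means among the compounds named here.

Of the compounds shown here, three sharing one core have been measured in an assay on HEK293 cells for inhibition of melanin-concentrating hormone receptor 1 (Homo sapiens), read by radioligand binding; a higher number here means a weaker inhibitor, a lower number a stronger inhibitor. Compound 1 (`CN(C)c1nc(N[C@H]2CC[C@@H](NC(=O)c3cccc(C#N)c3)CC2)nc2ccccc12`) gives 10 nM in this assay. Compound 3 (`CN(C)c1nc(NC2CCC(CNCc3ccc(Br)cc3OC(F)(F)F)CC2)nc2ccccc12`) gives 4.9 nM, and compound 2 (`CN(C)c1nc(N[C@H]2CC[C@@H](NS(=O)(=O)c3ccc(Br)cc3OC(F)(F)F)CC2)nc2ccccc12`) gives 83 nM. Among these three numbers, compound 1 stands second highest: compound 3 lies closest, with a lower number that is still beyond the usual scatter, while compound 2 is furthest away, with a clearly higher number. Compound 2 and compound 3 differ from compound 1 in more than one place, so no single step can be read from them.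

Compound 4 (`CN(C)c1nc(N[C@H]2CC[C@@H](NC(=O)c3ccc(Cl)c(Cl)c3)CC2)nc2ccccc12`) has not yet been measured. It differs from compound 1 in one place: 3,4-dichlorophenyl in place of 3-cyanophenyl on a carbonyl carbon. Nothing in the measured set isolates this kind of swap, so the expectation rests on the amide of compound 1 being kept intact. The step from compound 1 to compound 4 is expected to be small, a 1.3-fold lower number from compound 1 to compound 4 (0.10 log units; within the scatter), with no direction that clearly exceeds the scatter. Compound 4 is therefore estimated at 8 nM in this assay, with a plausible range from 2.5 nM to 30 nM.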

Compound 4, half-maximal inhibitory concentration: 5 nM
The estimate for compound 4 lay 1.6-fold (0.20 log units) above the measured number; the range from low to high includes it.
By their numbers in this assay, from the lowest: compounds 3, 4 and 1 (each within the scatter of the next, the first and the last beyond it); then compound 2.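

In this assay, placing 3,4-dichlorophenyl where 3-cyanophenyl stood on the carbonyl carbon gives a 2.0-fold lower number from compound 1 to compound 4 (0.30 log units; within the scatter), so the two compounds cannot be told apart here. For the compounds shown here, this is the first comparison in the set that changes only one place, and it shows that this position accepts two quite different groups without a change beyond the scatter, even though 3-cyanophenyl counts one hydrogen-bond acceptor and 3,4-dichlorophenyl none. No measurement at hand explains why these two groups read alike.

Going by these compounds, whether this position needs a substituent at all remains open, and a plain phenyl or a methoxyphenyl on the same carbonyl would help to settle that. Compound 2 and compound 3 differ from these amides in more than one place, so what the amide link itself contributes cannot be read from them.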